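Three measured aryl amides and an unmeasured pyrrole analogue

The source may report more compounds than this note shows. Statements on the series, on what has been measured and on what is new or still open speak of the compounds shown alone.

The three measured compounds share one core and differ only in the group on the carbonyl carbon. Compound 1 `CCN1CCN(c2cc(C)c3cc(NC(=O)c4cccc(Br)c4)ccc3n2)CC1` carries a 3-bromophenyl group and gives 13300 nM in a functional assay on SK-BR-3 cells (Homo sapiens) for antiproliferative activity, read by MTT assay, with a stated time of 72 h; on this read-out lower numbers stand for stronger inhibition and higher numbers for weaker inhibition. Compound 2 `CCN1CCN(c2cc(C)c3cc(NC(=O)c4ccc(F)c(F)c4)ccc3n2)CC1` carries a 3,4-difluorophenyl group; in this assay compound 2 gives 1980 nM. Compound 3 `CCN1CCN(c2cc(C)c3cc(NC(=O)c4ccc(Cl)c(Cl)c4)ccc3n2)CC1` carries a 3,4-dichlorophenyl group, and in this assay compound 3 gives 2160 nM. On these numbers compound 3 stands second highest: its nearest neighbour is compound 2 (a 1.1-fold higher number from compound 2 to compound 3 (0.04 log units; within the scatter)) and its furthest is compound 1 (a 6.2-fold lower number from compound 1 to compound 3 (0.79 log units; beyond the scatter)). The two steps from compound 1 (a 6.7-fold lower number from compound 1 to compound 2 (0.83 log units; beyond the scatter) and a 6.2-fold lower number from compound 1 to compound 3 (0.79 log units; beyond the scatter)) show that exchanging one halophenyl for another can move the number beyond the scatter, while the step between the two dihalophenyl compounds stays within it.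

Compound 4 `CCN1CCN(c2cc(C)c3cc(NC(=O)c4ccc[nH]4)ccc3n2)CC1` makes a change of a different kind: 1H-pyrrol-2-yl in place of 3,4-dichlorophenyl on a carbonyl carbon. Going by the values given here, no measured step involves a five-membered heteroaromatic ring on the carbonyl carbon, so none bears on it directly; the measured steps only mark the span that a change at this position has covered. Compound 4 is therefore estimated near the middle of that span, with a wide band. The step is expected to be a 2.3-fold higher number from compound 3 to compound 4 (0.36 log units; beyond the scatter). Compound 4 is expected to give about 5000 nM in this assay, between 1500 nM and 20000 nM.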

Compound 4, half-maximal inhibitory concentration: 13200 nM
Beside the measured number, compound 4's estimate is 2.6-fold (0.42 log units) below it, and the stated range covers the measured number.
By their numbers in this assay, from the lowest: compounds 2 and 3 (each within the scatter of the next); then compounds 4 and 1 (each within the scatter of the next).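

The 1H-pyrrol-2-yl group does not hold the level of the two dihalophenyl amides in this assay: the change gives a 6.1-fold higher number from compound 3 to compound 4 (0.79 log units; beyond the scatter) and a 6.7-fold higher number from compound 2 to compound 4 (0.82 log units; beyond the scatter), both beyond the scatter. Against the 3-bromophenyl amide it gives a 1.0-fold lower number from compound 1 to compound 4 (0.00 log units; within the scatter), within the scatter, so a five-membered aromatic ring with one hetero atom and a phenyl ring with a single bromine cannot be told apart here, and the four compounds fall into two groups, compound 2 with compound 3 and compound 1 with compound 4. This shows that the earlier span at this position is not limited to exchanges among halophenyl groups, though nothing at hand accounts for why the pyrrole and the 3-bromophenyl group read alike.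

The compounds shown leave open how furan-2-yl, thiophen-2-yl or a pyrrol-2-yl group with a methyl on its nitrogen would read on the same carbonyl carbon. Going by these compounds, it also remains open whether a phenyl ring with a single chlorine or fluorine, or with an amine or a carboxylic acid, would fall with compound 1 and compound 4 or with compound 2 and compound 3.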